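The source may report more compounds than this note shows. Statements on the series, on what has been measured and on what is new or still open speak of the compounds shown alone.

Measured in a functional assay (Homo sapiens) for antiproliferative activity; on this read-out lower numbers stand for stronger inhibition of growth and higher numbers for weaker inhibition of growth:
compound 1 `Cc1cn2c(/C=N/NC(=N)N)c(-c3ccncc3)nc2s1`: 9770 nM
compound 2 `N=C(N)N/N=C/c1c(-c2ccccn2)nc2sc(Cl)cn12`: 4370 nM
compound 3 `N=C(N)N/N=C/c1c(-c2cccnc2)nc2sc(Cl)cn12`: 13800 nM

Within the data shown here, compound 3 , at 13800 nM, lies within the scatter of compound 1 and is separated from compound 2 by the one measured step, a 3.2-fold higher number from compound 2 to compound 3 (0.50 log units; beyond the scatter). The next structure is compound 4 `N=C(N)N/N=C/c1c(-c2ccncc2)nc2sc(Cl)cn12`, which has pyridin-4-yl in place of pyridin-3-yl on an aromatic carbon. Among the measured compounds shown here, only one measured step bears directly on this exchange. That step, a 3.2-fold higher number from compound 2 to compound 3 (0.50 log units; beyond the scatter), shows that changing one pyridinyl group for another at this place can move the number beyond the scatter, but it gives no direction for the new change. Compound 1 also carries pyridin-4-yl and gives 9770 nM, yet it differs from compound 4 elsewhere, so it offers only a loose guide. A change of modest size at most is therefore expected, quite possibly none beyond the scatter. The expected step is a 1.4-fold lower number from compound 3 to compound 4 (0.14 log units; within the scatter). Compound 4 is estimated at 10000 nM, with an expected range from 4500 nM to 22000 nM.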

Compound 4, concentration for 50% growth inhibition: 3800 nM
Estimate against measurement, compound 4: 2.6-fold (0.42 log units) above; measured number outside the range, below it.
By their numbers in this assay, from the lowest: compounds 4 and 2 (each within the scatter of the next); then compounds 1 and 3 (each within the scatter of the next).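

In this assay, this position on the aromatic carbon responds to where the nitrogen lies in the pyridine ring, and the second measured exchange there shows pyridin-3-yl as the one that stands apart (a 3.6-fold lower number from compound 3 to compound 4 (0.56 log units; beyond the scatter)), while pyridin-2-yl and pyridin-4-yl are not separated (a 1.2-fold lower number from compound 2 to compound 4 (0.06 log units; within the scatter)). With pyridin-4-yl held fixed, chloro in place of methyl on the other aromatic carbon also moves the number beyond the scatter (a 2.6-fold lower number from compound 1 to compound 4 (0.41 log units; beyond the scatter)). No measurement offered here accounts for either effect.

As far as these compounds go, it remains open whether a plain phenyl ring or a ring bearing an amine at this position would give numbers like those of compound 2 and compound 4. From the compounds shown here alone, it is also open how bromo or a longer chain would compare with chloro on the core of compound 4.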